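Adding a Propyl Chain to Compound 3

The source may report more compounds than this note shows. Statements on the series, on what has been measured and on what is new or still open speak of the compounds shown alone.

Three compounds share one core and differ only in a group on a saturated chain carbon bound to an oxygen on an aromatic ring. In a functional assay on aorta (Rattus norvegicus, strain Sprague-Dawley) for inhibition (a lower number here means that less compound is needed, a higher number that more compound is needed for the effect), compound 3 `COc1cc2c(c3c1C[C@@H]1[C@@H](C)CO[C@]1(C)O3)C[C@@H]1[C@@H](C)CO[C@]1(C)O2` gives 33000 nM. Compound 2 `C#CCOc1cc2c(c3c1C[C@@H]1[C@@H](C)CO[C@]1(C)O3)C[C@@H]1[C@@H](C)CO[C@]1(C)O2` gives 22000 nM. The gap is a 1.5-fold higher number from compound 2 to compound 3 (0.18 log units; within the scatter), so these two count as level. Among the compounds with values here, compound 1 `CCCOc1cc2c(c3c1C[C@@H]1[C@@H](C)CO[C@]1(C)O3)C[C@@H]1[C@@H](C)CO[C@]1(C)O2` gives 77000 nM, the only clearly separate value of the three.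

The next compound to consider is compound 4 `CCCCOc1cc2c(c3c1C[C@@H]1[C@@H](C)CO[C@]1(C)O3)C[C@@H]1[C@@H](C)CO[C@]1(C)O2`, and the change is propyl in place of hydrogen on a saturated chain carbon bound to an oxygen on an aromatic ring: propyl in place of hydrogen, or methoxy to butoxy.

The closest guide is compound 1, which carries ethyl where compound 3 carries hydrogen. The measured step is a 2.3-fold lower number from compound 1 to compound 3 (0.37 log units; beyond the scatter), so read in reverse, adding ethyl gave a modestly higher number. The step of a 3.5-fold lower number from compound 1 to compound 2 (0.54 log units; beyond the scatter) involves ethynyl, a different kind of group, and bears on this change less directly. Propyl is a longer saturated chain than ethyl, but a single step cannot establish a trend with chain length, so the expectation remains loose.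

In this assay, the expected change is a modest rise of similar size, estimated as a 2.6-fold higher number from compound 3 to compound 4 (0.41 log units; beyond the scatter). For compound 4 the estimated value is 85000 nM, with an expected range from 35000 nM to 200000 nM.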

Compound 4, half-maximal effective concentration: > 200000 nM
Compound 4 ended at the assay's limit (the forecaster's own chance of this, stated with the estimate: 15%); middle value at least 2.3-fold (0.37 log units) away from the limit.
By their numbers in this assay, from the lowest: compounds 2 and 3 (each within the scatter of the next); then compound 1. At a limit, above all of these: compound 4.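

In this assay, compound 4 gives no exact number, only a limit of the assay: the limit of > 200000 nM in this assay, at which 1 of the 4 values shown sits.

Even so, the saturated chains now form a short series in which the number rises with each lengthening, with an at least 6.0-fold higher number from compound 3 to compound 4 (0.78 log units; beyond the scatter), and adding a single methyl still gives an at least 2.5-fold higher number from compound 1 to compound 4 (0.41 log units; beyond the scatter), so what one step could not establish now holds across three compounds. Within the data shown here, compound 2 goes against chain length as the sole guide, since its chain ending in ethynyl gives 22000 nM, and the butoxy chain stands far from it, with an at least 9.0-fold higher number from compound 2 to compound 4 (0.95 log units; beyond the scatter).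

Going by these compounds, how far the true value of compound 4 lies from the limit stays unknown, so the full size of these rises and the shape of the trend remain unsettled. Also open, on these data alone, is whether a still longer chain, a branched chain such as isopropyl, or an amine or a carboxylic acid at the chain end would continue the rise or bring the number back down.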